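Lipophilicity across the shared hydrazide core, compound 4 pending

The compounds below may be only part of what the source reports. "The series", "measured", "known", "first", "only" and "open" are said of these compounds alone.

Measured so far in a physicochemical assay for lipophilicity, measured as octanol-water partition; a lower number here means a more polar compound, a higher number a more lipophilic compound:
compound 1 `COc1ccc(/C=N/c2ccccc2C(=O)NNc2ccnc3cc(Cl)ccc23)cc1` gives 5;
compound 2 `O=C(NNc1ccnc2cc(Cl)ccc12)c1ccccc1/N=C/c1ccc([N+](=O)[O-])cc1` gives 4.58;
compound 3 `CN(C)c1ccc(/C=N/c2ccccc2C(=O)NNc2ccnc3cc(Cl)ccc23)cc1` gives 5.03.

Compound 1 stands second highest of the three numbers. Its nearest neighbour is compound 3, with a number 0.03 log units higher from compound 1 to compound 3 (within the scatter), a difference within the scatter, so no order between the two can be read. The furthest is compound 2, with a number 0.42 log units lower from compound 1 to compound 2 (beyond the scatter), and a number 0.45 log units higher from compound 2 to compound 3 (beyond the scatter) closes the set.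

Compound 4 `O=C(NNc1ccnc2cc(Cl)ccc12)c1ccccc1/N=C/c1cc2ccccc2nc1Cl` is not yet measured in this assay. It differs from compound 1 thus: 2-chloroquinolin-3-yl in place of 4-methoxyphenyl on a carbon with a double bond to nitrogen. Among the compounds with values here, none of the measured steps bears directly on this change: each of them swaps one group on an aromatic carbon of the departing 4-methoxyphenyl and leaves that ring in place, whereas here the whole ring is replaced by 2-chloroquinolin-3-yl. The measured steps therefore set only the scale of modest variation seen so far, and the entering group counts more heavy atoms and a second aromatic ring, so a step upward beyond the scatter is expected, larger than any of the three measured ones. For compound 4 the expected step is a number 1.00 log units higher from compound 1 to compound 4 (beyond the scatter). Compound 4 is estimated at 6, with a range from 5.3 to 6.7.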

Compound 4, partition coefficient: 6
Estimate against measurement, compound 4: no gap at the digits printed, within the range that was stated.
By their numbers in this assay, from the lowest: compound 2; then compounds 1 and 3 (each within the scatter of the next); then compound 4.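

Replacing the whole ring on this carbon with a double bond to nitrogen gives a larger step than any swap of a group on that ring: in this assay the change reads a number 1.00 log units higher from compound 1 to compound 4 (beyond the scatter) and from the other two compounds it reads a number 0.97 log units higher from compound 3 to compound 4 (beyond the scatter) and a number 1.42 log units higher from compound 2 to compound 4 (beyond the scatter) for the same entering group. Compound 4 therefore stands apart from all three earlier compounds, with each step beyond the scatter. No supporting measurement accounts for this rise.

On these data alone, the entering group differs in several ways at once, so the separate shares of the chlorine, the ring nitrogen and the second aromatic ring remain open. Also open, as far as these compounds go, is where the number would lie with a carboxylic acid or an aliphatic amine in place of 2-chloroquinolin-3-yl.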